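The source may report more compounds than this note shows. Statements on the series, on what has been measured and on what is new or still open speak of the compounds shown alone.

Working notes on the series. Compound 1 `O=c1c2ccccc2c(Cc2ccc(Cl)cc2)nn1-c1ccc([N+](=O)[O-])cc1` in a functional assay on aorta with Alpha-1D adrenergic receptor (Rattus norvegicus) as the target (a lower number here means that less compound is needed, a higher number that more compound is needed for the effect), gives 29000 nM. Going by the values given here, compound 2 `C=CCn1nc(Cc2ccc(Cl)cc2)c2ccccc2c1=O` differs from it only on the aromatic nitrogen and in this assay gives 2600 nM, so that the step of an 11-fold lower number from compound 1 to compound 2 (1.05 log units; beyond the scatter) is the one measured change in the set that moves the number. Compound 3 `CCCCn1nc(Cc2ccc(SC)cc2)c2ccccc2c1=O` carries a butyl on that nitrogen and a methylsulfanyl on the pendant ring; in this assay compound 3 reaches only a limit, > 100000 nM, and no number. On the numbers shown, compound 3 stands at the limit of the assay (the limit of > 100000 nM in this assay, at which 1 of the 3 values shown sits), the least informative position in the set, with no measured step that leads to or from it.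

Compound 4 `CCCCn1nc(Cc2ccc(Cl)cc2)c2ccccc2c1=O` is the next step: chloro in place of methylsulfanyl on an aromatic carbon, the 4-(methylsulfanyl)phenyl becoming 4-chlorophenyl. Among the compounds with values here, no measured step covers a change at this aromatic carbon; the step of an 11-fold lower number from compound 1 to compound 2 (1.05 log units; beyond the scatter) sits on the nitrogen and bears on the present change only in showing that this scaffold can move by that much. Compound 2 shows that a 4-chlorophenyl on this core can reach a measurable number, whereas compound 3, with methylsulfanyl, did not. A step toward a lower number is therefore expected, and the expected step is estimated as an at least 6.6-fold lower number from compound 3 to compound 4 (0.82 log units; beyond the scatter). Compound 4 is expected at 15000 nM, within 4000 nM to 60000 nM.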

Compound 4, half-maximal effective concentration: > 100000 nM
Compound 4: a limit, no number; the forecaster's own chance of this, stated with the estimate: 25%; at least 6.6-fold (0.82 log units) between middle value and limit.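

In this assay compound 4 gives > 100000 nM, a limit and not a number, so the 4-chlorophenyl alone does not bring a compound with butyl on the nitrogen to a measurable number, and the step from compound 3, with both values at limits, cannot be read. The group on the nitrogen now stands out as a place of large change, with an at least 38-fold higher number from compound 2 to compound 4 (1.58 log units; beyond the scatter) for propyl in place of vinyl on the saturated chain carbon bound to the aromatic nitrogen, and an at least 3.4-fold higher number from compound 1 to compound 4 (0.53 log units; beyond the scatter) for butyl in place of 4-nitrophenyl on the aromatic nitrogen. Compound 3 and compound 4 share the butyl, differ on the pendant ring and both stand at the limit: the limit of > 100000 nM in this assay, at which 2 of the 4 values shown sit.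

As far as these compounds go, whether methylsulfanyl and chloro differ at all on the pendant ring stays open, as neither butyl compound gives a number. Also open, from the compounds shown here alone, is whether the lower number of compound 2 goes with the double bond of the allyl or with the shorter chain: a saturated propyl on the nitrogen would separate the two, and an amine at the end of that chain would test a further kind of group there.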